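Two stereoisomers against a galactosaminidase

A few compounds are considered here, and "the series" means these few. Any claim that something is new, unique, unknown or untested is made for them only; others in the source may bear on it.

Measured compounds:
compound 1 `O=C(O)[C@H]1NCC=C[C@H]1O` — 0.2%
compound 2 `O=C(O)[C@@H]1NC[C@@H](O)[C@H](O)[C@@H]1O` — 10%

In an assay for inhibition of alpha-N-acetylgalactosaminidase (Gallus gallus), tested at 1000 uM (a lower number here means less inhibition, a higher number more inhibition at the concentration tested (going by the name of the read-out)), compound 1 gives 0.2%. In this assay compound 2 gives 10%, the higher of the two numbers, though the gap between compound 2 and compound 1 lies within the usual scatter, so the two cannot be ordered on these data.

Compound 3 `O=C(O)[C@H]1NC[C@@H](O)[C@@H](O)[C@@H]1O` has not been measured in this assay. Relative to compound 2 the change is the two compounds have the same atoms and bonds and differ only in configuration as drawn: 2 of 4 stereo elements differ; a stereocentre at a saturated ring carbon is drawn R in compound 2 and S in compound 3; a stereocentre at a saturated ring carbon is drawn S in compound 2 and R in compound 3.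

Among the measured compounds shown here, no step between two measured compounds is available, and the two numbers in hand are both small and indistinguishable from each other. The expectation for this assay is therefore a step from compound 2 to compound 3 of no change at the digits printed from compound 2 to compound 3 (within the scatter), that is, no change beyond the scatter in either direction. Compound 3 is estimated to give 10%, with a range from 0% to 35%.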

Compound 3, a percentage reported as inhibition, at one concentration (the size of the read-out at that concentration, not a potency): 3.8%
The estimate for compound 3 lay 6.2 percentage points above the measured number; the measured number falls inside the stated range.
By their numbers in this assay, from the lowest: compounds 1, 3 and 2 (each within the scatter of the next).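

In this assay, among the compounds shown here, the pair gives the first step that can be read at all, a number 6.2 percentage points lower from compound 2 to compound 3 (within the scatter). Swapping the configuration at two of the four stereo elements, with atoms and bonds unchanged, therefore moves the read-out by no more than the scatter, so this double change does not separate the two compounds at the concentration tested. All that sets them apart is stereochemistry: the fact that compounds 2 and 3 differ only in the configuration as drawn

Since the two stereocentres change together, the step does not show what either saturated ring carbon would do if its configuration changed alone. As far as these compounds go, how this assay would respond to an acetamido group on the shared core, or to a methyl ester in place of the carboxylic acid, also remains open.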